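A few compounds are considered here, and "the series" means these few. Any claim that something is new, unique, unknown or untested is made for them only; others in the source may bear on it.

Of the compounds shown here, three sharing one core have been tested in a functional assay on 2008 cells (Homo sapiens) for cytotoxicity, read by MTT assay, with a stated time of 68 h; a lower number here means a stronger inhibitor, a higher number a weaker inhibitor. Compound 1 `O=C(/C=C/c1cccc(OCc2ccccc2)c1)c1ccc([N+](=O)[O-])cc1` gives 49000 nM, compound 3 `O=C(/C=C/c1cccc(OCc2ccccc2)c1)c1ccc(O)cc1` gives 800 nM, and compound 2 `O=C(/C=C/c1cccc(OCc2ccccc2)c1)c1ccc(Cl)cc1Cl` gives 5200 nM, the second highest of the three numbers. Compound 4 `Cc1ccc(C(=O)/C=C/c2cccc(OCc3ccccc3)c2)cc1` has not yet been measured. It differs from compound 2 in one place, with 4-methylphenyl in place of 2,4-dichlorophenyl on a carbonyl carbon.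

All three measured steps change the group at this same place. The number falls by a 9.4-fold lower number from compound 1 to compound 2 (0.97 log units; beyond the scatter), then by a 6.5-fold lower number from compound 2 to compound 3 (0.81 log units; beyond the scatter), and the whole span is a 61-fold lower number from compound 1 to compound 3 (1.79 log units; beyond the scatter). Changes here can therefore matter, and each measured step lies beyond the scatter. However, no measured compound carries the 4-methylphenyl group, so the direction is poorly grounded. A small move towards a lower number is only a tentative expectation, and it may not exceed the scatter. The expected step is a 1.7-fold lower number from compound 2 to compound 4 (0.24 log units; within the scatter). For compound 4 the estimated value is 3000 nM, with an expected range from 800 nM to 12000 nM.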

Compound 4, half-maximal inhibitory concentration: 12900 nM
For compound 4 the middle estimate is 4.3-fold (0.63 log units) below the measured one; measured number above the stated range.
By their numbers in this assay, from the lowest: compound 3; then compound 2; then compound 4; then compound 1.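

In this assay the 4-methylphenyl group falls inside the span already seen at this place, giving a 2.5-fold higher number from compound 2 to compound 4 (0.39 log units; beyond the scatter) and so ranking on the weaker side of 2,4-dichlorophenyl. Methyl also sits between the other two single groups on this ring: putting it in place of hydroxy gives a 16-fold higher number from compound 3 to compound 4 (1.21 log units; beyond the scatter) and putting it in place of nitro gives a 3.8-fold lower number from compound 1 to compound 4 (0.58 log units; beyond the scatter), so hydroxy, methyl and nitro give three separate levels of activity. Nothing measured here explains why the groups fall in this order.

The compounds shown leave open how an amine, a carboxylic acid or a methoxy group would behave on this aromatic carbon. They also leave open whether this order would hold after a change elsewhere on the shared core.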